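Benzyl in place of 2-chlorophenyl: working notes

The source may report more compounds than this note shows. Statements on the series, on what has been measured and on what is new or still open speak of the compounds shown alone.

Measured in a functional assay on U-373MG ATCC cells (Homo sapiens) for inhibition, read by MTT assay, with a stated time of 72 h; a higher number here means a weaker inhibitor, a lower number a stronger inhibitor:
- compound 1 `CC1(C)CC(NC(=O)Nc2ccccc2Cl)c2cc(F)ccc2O1` gives 40000 nM
- compound 2 `CC1(C)CC(NC(=O)Nc2ccccc2Cl)c2cc(Cl)ccc2O1` gives 17000 nM
- compound 3 `CC(C)NC(=S)NC1CC(C)(C)Oc2ccc(Cl)cc21` gives 57000 nM

Compound 1, at 40000 nM in this assay, sits within the scatter of compound 3, and only compound 2 has a clearly lower number. The change under review leads to compound 4 `CC1(C)CC(NC(=O)NCc2ccccc2)c2cc(F)ccc2O1` and reads (benzyl in place of 2-chlorophenyl on an amide-type nitrogen), in short benzyl in place of 2-chlorophenyl on an amide-type nitrogen.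

Within the data shown here, the one measured step is a 2.4-fold lower number from compound 1 to compound 2 (0.37 log units; beyond the scatter), with chloro in place of fluoro on an aromatic carbon. That step is modest and sits at a different place, so it gives no direct measure of the new change. Among the measured compounds shown here, no measured step covers a change on the amide-type nitrogen. Compound 3 also lacks the 2-chlorophenyl and gives 57000 nM, close to the value of compound 1, but it differs in more than that one place and is only weak support.

No step beyond the scatter is therefore expected, and any drift is expected towards a slightly higher number. For compound 4 the estimated value is 50000 nM, with an expected range from 20000 nM to 130000 nM. The estimate amounts to a 1.3-fold higher number from compound 1 to compound 4 (0.10 log units; within the scatter) in this assay.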

Compound 4, half-maximal inhibitory concentration: 11000 nM
Compound 4: middle estimate off by 4.5-fold (0.66 log units), on the high side; the whole stated range lies above it.
By their numbers in this assay, from the lowest: compounds 4 and 2 (each within the scatter of the next); then compounds 1 and 3 (each within the scatter of the next).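

Among these compounds, the position on the amide-type nitrogen responds to substitution: in this assay the change to benzyl in place of 2-chlorophenyl gives a 3.6-fold lower number from compound 1 to compound 4 (0.56 log units; beyond the scatter), the first measured step at this place. Together with a 2.4-fold lower number from compound 1 to compound 2 (0.37 log units; beyond the scatter), it shows that two separate places on this scaffold each carry a step beyond the scatter, although both steps remain modest. The two groups exchanged here have the same count of 7 heavy atoms and the same single six-membered aromatic ring of carbon only, so these counts do not separate them, and no measured evidence on hand accounts for the step.

The step combines two differences, the loss of chlorine and the change from (2-chlorophenyl)amino to benzylamino, and the compounds shown do not separate them; an unsubstituted phenyl and a 2-chlorobenzyl group on the same nitrogen would do so. Also open, from the compounds shown here alone, are how a longer chain such as phenethyl, or a benzyl group carrying an amine or a carboxylic acid, would read in this assay, and whether chloro in place of fluoro on the aromatic carbon would give a further step with benzyl present.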